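Swapping Anilino for 4-Nitrophenyl on the Carbonyl Carbon

A few compounds are considered here, and "the series" means these few. Any claim that something is new, unique, unknown or untested is made for them only; others in the source may bear on it.

Compound 3 `CC1=CC[C@H](C(C)C)c2cc(C)c(OC(=O)Nc3ccccc3)cc21` gives 92.6% in a functional assay on K562 cells (Homo sapiens) for antiproliferative activity, read by sulforhodamine B assay, with a stated time of 48 h, tested at 50 uM; on this read-out lower numbers stand for less inhibition and higher numbers for more inhibition at the one concentration tested (going by the name of the read-out); this is the lower of the two numbers, yet within the scatter of compound 2 `CC1=CC[C@H](C(C)C)c2cc(C)c(OC(=O)c3ccc(C)cc3)cc21`, which gives 100%, while compound 1 `COc1cccc(C(=O)Oc2cc3c(cc2C)[C@@H](C(C)C)CC=C3C)c1` is reported as "not active" (no number reported) with no figure. Compound 4 `CC1=CC[C@H](C(C)C)c2cc(C)c(OC(=O)c3ccc([N+](=O)[O-])cc3)cc21` differs from compound 3 by 4-nitrophenyl in place of anilino on a carbonyl carbon. For the measured compounds named here, the only measured step at this carbonyl carbon is a number 7.4 percentage points lower from compound 2 to compound 3 (within the scatter), a change within the scatter, so exchanging the group on this carbon has so far left inhibition in this assay essentially unchanged, apart from the unnumbered result of compound 1. Compound 4 is therefore expected to stay high, with an estimated step of a number 7.6 percentage points lower from compound 3 to compound 4 (within the scatter) and an estimated value of 85% (range 40% to 100%).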

Compound 4, a percentage reported as inhibition, at one concentration (the size of the read-out at that concentration, not a potency): 89%
Compound 4: the middle estimate sits 4 percentage points below what was measured, within the range that was stated.
By their numbers in this assay, from the lowest: compounds 4, 3 and 2 (each within the scatter of the next, the first and the last beyond it).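

Within this assay, 4-nitrophenyl in place of anilino on the carbonyl carbon removes the hydrogen-bond donor of anilino and gives a number 3.6 percentage points lower from compound 3 to compound 4 (within the scatter). For the compounds shown here, the change of nitro in place of methyl on an aromatic carbon gives a number 11 percentage points lower from compound 2 to compound 4 (beyond the scatter), the first numbered step to pass the scatter. No measurement here explains either step.

As far as these compounds go, whether an amine or a carboxylic acid in place of nitro on that aromatic carbon would keep inhibition this high remains open. Results at a single concentration also leave the potency of these compounds open.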